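The source may hold more compounds than are shown below. What is called first, only, known or untested is meant among the compounds shown, and "the series" means these compounds.

Three compounds of the shared core have numbers in an assay on HEK293 cells for inhibition of Steryl-sulfatase (Homo sapiens), tested at 1 uM; on this read-out lower numbers stand for a weaker effect and higher numbers for a stronger effect at the one concentration tested. Compound 1 `CN(C)CCN(CCN(C)C)c1ccc(C(=O)N2CCc3ccc(OS(N)(=O)=O)cc3C2)cc1` gives 15.9%, compound 2 `CN(C)CCCN(Cc1ccccc1)c1cccc(C(=O)N2CCc3ccc(OS(N)(=O)=O)cc3C2)c1` gives 26%, and compound 3 `CCN(Cc1ccncc1)c1ccc(C(=O)N2CCc3ccc(OS(N)(=O)=O)cc3C2)cc1` gives 86.6%, the highest of the three, with compound 2 nearest and compound 1 furthest. Going by the values given here, the single step measured in one place, a number 70.7 percentage points higher from compound 1 to compound 3 (beyond the scatter), exchanges the whole substituent on an aromatic carbon and is large. Compound 4 `CCN(Cc1cccc(Br)c1)c1ccc(C(=O)N2CCc3ccc(OS(N)(=O)=O)cc3C2)cc1` differs from compound 3 by 3-bromophenyl in place of pyridin-4-yl on a saturated chain carbon bound to a nitrogen on an aromatic ring. Among the compounds with values here, no measured step exchanges the ring on that chain carbon; compound 2, differing in more than one place, shows only its own lower number. A step of at most moderate size is expected in this assay, direction uncertain, so compound 4 is expected to give 75%, between 45% and 95%. This expectation means a step of a number 11.6 percentage points lower from compound 3 to compound 4 (beyond the scatter).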

Compound 4, a percentage reported as inhibition, at one concentration (the size of the read-out at that concentration, not a potency): 97.2%
Compound 4: the middle estimate sits 22.2 percentage points below what was measured; the measured number lies above the stated range.
By their numbers in this assay, from the lowest: compound 1; then compound 2; then compound 3; then compound 4.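

In this assay, the ring on the saturated chain carbon bound to a nitrogen on an aromatic ring can go from pyridin-4-yl to 3-bromophenyl with no loss, giving a number 10.6 percentage points higher from compound 3 to compound 4 (beyond the scatter). The ring nitrogen of pyridin-4-yl is therefore not required for a high number in this pair, and the gain over the bis(2-(dimethylamino)ethyl)amino substituent grows to a number 81.3 percentage points higher from compound 1 to compound 4 (beyond the scatter). No evidence is available on what lies behind the rise. Still open, from the compounds shown here alone, are the contribution of the bromine itself, and what unsubstituted phenyl, chlorine in place of the bromine, or a longer chain in place of the ethyl would give.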